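Sulfamoyl to cyano on the anilino ring of compound 2

This account rests on a few compounds, and the source may have more. Where it says the series, first, only, none or still open, it means among the compounds named here.

Measured compounds:
compound 1 `Cc1cc(NS(=O)(=O)c2ccc(Nc3nncc4ccccc34)cc2)no1` 35 nM
compound 2 `NS(=O)(=O)c1ccc(Nc2nncc3ccccc23)cc1` 14 nM
compound 3 `O=S(=O)(Nc1ncccn1)c1ccc(Nc2nncc3ccccc23)cc1` 45 nM

In a functional assay on DU-145 cells (Homo sapiens) for antiproliferative activity, read by sulforhodamine B assay, with a stated time of 72 h (a higher number here means a weaker inhibitor, a lower number a stronger inhibitor), compound 2 gives the lowest number of the three; its nearest neighbour is compound 1, a 2.5-fold lower number from compound 1 to compound 2 (0.40 log units; beyond the scatter), and its furthest is compound 3, a 3.2-fold higher number from compound 2 to compound 3 (0.51 log units; beyond the scatter). Compound 1 and compound 3 sit within the scatter of each other, a 1.3-fold higher number from compound 1 to compound 3 (0.11 log units; within the scatter).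

Compound 4 `N#Cc1ccc(Nc2nncc3ccccc23)cc1` is not yet measured in this assay. It differs from compound 2 in one place: cyano in place of sulfamoyl on an aromatic carbon. For the measured compounds named here, the measured steps all change what sits on the sulfonamide nitrogen, and none exchanges the sulfamoyl itself, so no step bears directly on this change. Those steps were modest in both directions, which suggests the end of the molecule is not highly sensitive, but the loss of the whole sulfamoyl is a larger change than any measured. For compound 4 a modest rise in number is expected, a 2.9-fold higher number from compound 2 to compound 4 (0.46 log units; beyond the scatter), with a wide range. The estimate for compound 4 in this assay is 40 nM, between 10 nM and 160 nM.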

Compound 4, half-maximal inhibitory concentration: 2.1 nM
The estimate for compound 4 lay 19-fold (1.28 log units) above the measured number; the whole stated range lies above it.
By their numbers in this assay, from the lowest: compound 4; then compound 2; then compounds 1 and 3 (each within the scatter of the next).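

In this assay, the sulfamoyl group is not needed for a low number at this position on the anilino ring: its replacement by cyano gives a 6.7-fold lower number from compound 2 to compound 4 (0.82 log units; beyond the scatter). The earlier steps shown here changed only what sits on the sulfonamide nitrogen, and both substituents there raised the number relative to compound 2, whereas this exchange removes the whole group, including its hydrogen-bond donor, and the number falls. Nothing available here accounts for the gain in potency.

For the compounds shown here, the single exchange does not separate the effect of losing sulfamoyl from that of gaining cyano. A plain hydrogen, a chlorine, a carboxamide or a carboxylic acid on the same aromatic carbon would help to tell these apart and show how specific the gain is to cyano.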